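Dimethylamino in place of propyl on the ester chain

The source may report more compounds than this note shows. Statements on the series, on what has been measured and on what is new or still open speak of the compounds shown alone.

Compound 1, `C[S+]([O-])c1c(F)c(N)c2c(=O)cc(-c3ccc(N)c(F)c3)oc2c1F`, in a functional assay on HeLa cells (Homo sapiens) for cytotoxicity, read by neutral red uptake, with a stated time of 3 days (on this read-out higher numbers stand for weaker inhibition and lower numbers for stronger inhibition), gives > 100000 nM, which is a limit of the assay rather than a number.
Compound 2, `Nc1ccc(-c2cc(=O)c3c(N)c(F)c(Cl)c(F)c3o2)cc1F`, in this assay gives > 100000 nM, again a limit.
Compound 3, `CCCCCC(=O)OCc1c(F)c(N)c2c(=O)cc(-c3ccc(N)c(F)c3)oc2c1F`, in this assay gives 34000 nM.

Compound 3 therefore holds the only readable number in the set; the other two values sit at the limit, as shown by the limit of > 100000 nM in this assay, at which 2 of the 3 values shown sit. The step of an at least 2.9-fold lower number from compound 1 to compound 3 (0.46 log units; beyond the scatter) and the step of an at least 2.9-fold lower number from compound 2 to compound 3 (0.46 log units; beyond the scatter) both bring the number down from the limit, whereas a step that the two limits leave unreadable from compound 1 to compound 2, since both ends are limits, cannot be read at all.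

Compound 4, `CN(C)CCC(=O)OCc1c(F)c(N)c2c(=O)cc(-c3ccc(N)c(F)c3)oc2c1F`, differs from compound 3 by dimethylamino in place of propyl on a saturated chain carbon, two bonds along the chain from a carbonyl carbon. Each of the three measured steps changes what is attached to an aromatic carbon of the shared core, and none of them alters the chain of the ester; so no measured step bears directly on this change, and the data give no reason to expect a shift in either direction beyond the scatter. The estimate for compound 4 in this assay is 34000 nM, expected to lie between 12000 nM and 100000 nM. The expected step is no change at the digits printed from compound 3 to compound 4 (within the scatter), within the scatter.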

Compound 4, half-maximal inhibitory concentration: 11000 nM
Beside the measured number, compound 4's estimate is 3.1-fold (0.49 log units) above it; measured number below the stated range.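

The ester chain of this series is not a silent part of the molecule: in this assay, dimethylamino in place of propyl, on a saturated chain carbon, two bonds along the chain from a carbonyl carbon, gives a 3.1-fold lower number from compound 3 to compound 4 (0.49 log units; beyond the scatter). Among the compounds shown here, this is the only step in the set read between two real numbers, and the only one that leaves the group's attachment to the aromatic carbon of the shared core untouched, so it shows that an exchange far out on the chain can move the number beyond the scatter. The full ester group of compound 4 also gives an at least 9.0-fold lower number from compound 2 to compound 4 (0.95 log units; beyond the scatter) and an at least 9.0-fold lower number from compound 1 to compound 4 (0.95 log units; beyond the scatter), both larger than the corresponding steps to compound 3, though each starts from a limit and gives only a lower bound on its size: the limit of > 100000 nM in this assay, at which 2 of the 4 values shown sit.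

The compounds shown leave open whether the step belongs to the nitrogen itself or to the dimethylamino group as a whole, which a primary amine, a diethylamino group or a carboxylic acid at the same place on the chain would help to separate. They also leave open how the number responds to a longer chain between the carbonyl carbon and the dimethylamino group.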